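This account rests on a few compounds, and the source may have more. Where it says the series, first, only, none or still open, it means among the compounds named here.

Within the data shown here, compound 1 `CC1CCN(C2CCN(S(=O)(=O)c3cccc(N)c3)CC2)CC1` gives 3400 nM in a functional assay on DLD-1 cells (Homo sapiens) for antiproliferative activity, read by CellTiter-Glo, with a stated time of 72 h (a higher number here means a weaker inhibitor, a lower number a stronger inhibitor), the highest of the two numbers measured so far; its nearest neighbour is compound 2 `CC1CCN(C2CCN(S(=O)(=O)c3ccc(Br)c(Cl)c3)CC2)CC1`, which in this assay gives 12 nM. Among the measured compounds shown here, the one measured step, a 280-fold lower number from compound 1 to compound 2 (2.45 log units; beyond the scatter), comes with 4-bromo-3-chlorophenyl in place of 3-aminophenyl on the sulfonyl sulfur. Compound 3 `CC1CCN(C2CCN(S(=O)(=O)c3cccc(-c4ccc(Cl)cc4)c3)CC2)CC1`, not yet measured, differs from compound 1 by 4-chlorophenyl in place of amino on an aromatic carbon. For the measured compounds named here, the step from compound 1 to compound 2 bears on this change, since both remove the amino from the same ring and leave the rest of the shared core untouched; no measured compound carries a 4-chlorophenyl, so the size of the step is uncertain. A large step lower is expected for compound 3, a 43-fold lower number from compound 1 to compound 3 (1.63 log units; beyond the scatter), with a wide range around it. Compound 3 is estimated at 80 nM, between 15 nM and 450 nM.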

Compound 3, half-maximal inhibitory concentration: 15 nM
For compound 3 the middle estimate is 5.3-fold (0.73 log units) above the measured one, within the range that was stated.
By their numbers in this assay, from the lowest: compounds 2 and 3 (each within the scatter of the next); then compound 1.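

In this assay the place on the aromatic carbon held by amino in compound 1 tolerates a much larger group: 4-chlorophenyl, which adds a six-membered aromatic ring, brings a 230-fold lower number from compound 1 to compound 3 (2.36 log units; beyond the scatter). Together with a 280-fold lower number from compound 1 to compound 2 (2.45 log units; beyond the scatter), this makes two different replacements of the 3-aminophenyl arrangement that end in a much lower number, so the low values do not depend on the 4-bromo-3-chlorophenyl group alone, and no compound shown goes against this. Nothing on hand gives a reason for the step.

Going by these compounds, whether the drop follows from the loss of amino or from the group that enters stays open; a plain hydrogen or an unsubstituted phenyl at this place would separate the two. A carboxylic acid or a methoxy group here would show how far the low numbers extend beyond aryl and halogen groups.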